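The compounds below may be only part of what the source reports. "The series", "measured", "known", "first", "only" and "open" are said of these compounds alone.

Working notes on the series in an ADME assay on Huh-7 cells (Homo sapiens) for cytotoxicity, with a stated time of 72 h; a lower number here means that less compound is tolerated, a higher number that more compound is tolerated.

Compound 1 `CCC(C)(C)c1nn(CCC(C)C)c(=O)c(C2=NS(=O)(=O)c3cc(NS(C)(=O)=O)ccc3N2)c1O` carries a 1,1-dimethylpropyl group on the shared core. In this assay compound 1 reaches > 1000 nM, which is a limit of the assay and not a number. Compound 2 `CC(C)CCn1nc(CCC(F)(F)F)c(O)c(C2=NS(=O)(=O)c3cc(NS(C)(=O)=O)ccc3N2)c1=O` differs from it in one place, with 3,3,3-trifluoropropyl in place of 1,1-dimethylpropyl on an aromatic carbon. In this assay compound 2 reaches > 33000 nM, again a limit and not a number. The step that the two limits leave unreadable from compound 1 to compound 2 stays unreadable in size because the limit of > 1000 nM in this assay, at which 2 of the 3 values shown sit, and the limit of > 33000 nM in this assay, at which 1 of the 3 values shown sits, cap both ends of it.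

Compound 3 `CS(=O)(=O)Nc1ccc2c(c1)S(=O)(=O)N=C(c1c(O)c(-c3cccs3)nn(CC3CCC3)c1=O)N2` carries a cyclobutylmethyl group on the aromatic nitrogen of the core. In this assay compound 3 gives > 1000 nM, a limit and not a number. It sits, with one other value, at the limit of > 1000 nM in this assay, at which 2 of the 3 values shown sit; nothing in the series places a tolerated concentration anywhere but at a limit.

Compound 4 `CS(=O)(=O)Nc1ccc2c(c1)S(=O)(=O)N=C(c1c(O)c(-c3cccs3)nn(Cc3ccc(F)cc3)c1=O)N2` is not yet measured and differs from compound 3 by 4-fluorophenyl in place of cyclobutyl on a saturated chain carbon bound to an aromatic nitrogen, read one bond further out as cyclobutylmethyl to 4-fluorobenzyl. Among the compounds with values here, no measured step touches this change, and the only measured step is unreadable. The change is therefore expected to give no step beyond the scatter, a step that the limit leaves unreadable from compound 3 to compound 4. Compound 4 is expected at 20000 nM, within 3000 nM to 100000 nM, most likely again reported only as a limit.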

Compound 4, half-maximal cytotoxic concentration: > 1000 nM
Compound 4 was reported as a limit; the forecaster's own chance of this, stated with the estimate: 70%; the middle value does not contradict the limit.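

In this assay compound 4 gives > 1000 nM, a limit of the assay and not a number. No step can be read from compound 3 to compound 4, since both stand at the same limit: the limit of > 1000 nM in this assay, at which 3 of the 4 values shown sit.

The compounds shown leave open whether 4-fluorobenzyl in place of cyclobutylmethyl changes the tolerated concentration at all.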